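Swapping the piperidine aryl in a potent TRPV1 antagonist

This account rests on a few compounds, and the source may have more. Where it says the series, first, only, none or still open, it means among the compounds named here.

Compound 1, `CC(C(=O)NCc1ccc(C(F)(F)F)nc1N1CCCC1)c1ccc(NS(C)(=O)=O)c(F)c1`, 211 nM
Compound 2, `Cc1ccc(CC2CCN(c3nc(C(F)(F)F)ccc3CNC(=O)C(C)c3ccc(NS(C)(=O)=O)c(F)c3)CC2)cc1`, 17 nM

In a functional assay on CHO-K1 cells for antagonist activity at transient receptor potential cation channel subfamily V member 1 (Homo sapiens), read by FLIPR (on this read-out higher numbers stand for weaker inhibition and lower numbers for stronger inhibition), compound 2 gives 17 nM, the lowest of the two numbers recorded. Its nearest neighbour on this scale is compound 1, which in this assay gives 211 nM, a gap beyond the scatter. Going by the values given here, no single-point step between these two measured compounds is on hand, so only their two values can be compared.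

Compound 3, `CC(C(=O)NCc1ccc(C(F)(F)F)nc1N1CCC(Cc2cc(F)cc(F)c2)CC1)c1ccc(NS(C)(=O)=O)c(F)c1`, has not yet been measured. It differs from compound 2 by 3,5-difluorophenyl in place of 4-methylphenyl on a saturated chain carbon bound to a saturated ring carbon. Among the compounds with values here, no measured pair shows the effect of such a change, so the expectation rests on the closeness of the two aryl groups in size and shape. The step from compound 2 to compound 3 is expected to be small, a 1.5-fold higher number from compound 2 to compound 3 (0.17 log units; within the scatter), most likely none beyond the scatter. Compound 3 is therefore estimated at 25 nM, within 8 nM to 80 nM.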

Compound 3, half-maximal inhibitory concentration: 24 nM
Beside the measured number, compound 3's estimate is 1.0-fold (0.02 log units) above it; the range from low to high includes it.
By their numbers in this assay, from the lowest: compounds 2 and 3 (each within the scatter of the next); then compound 1.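

In this assay, placing 3,5-difluorophenyl in place of 4-methylphenyl on a saturated chain carbon bound to a saturated ring carbon gives a 1.4-fold higher number from compound 2 to compound 3 (0.15 log units; within the scatter), so this position takes either aryl group without a difference beyond the scatter. The change from 4-methylbenzyl to 3,5-difluorobenzyl thus swaps a methyl for two fluorines while the six-membered aromatic ring stays, and the read-out does not separate the two compounds. Nothing on hand speaks to the reason for this result.

Still open, going by these compounds, is how a pyridine ring in place of the aryl group, a carboxylic acid on that ring, or a longer chain carrying it would read. Also open, on these data alone, is how an unsubstituted phenyl would compare with both of these groups.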